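Para substituents on the phenyl ring and cytotoxicity

The source may hold more compounds than are shown below. What is called first, only, known or untested is meant among the compounds shown, and "the series" means these compounds.

Compound 1 `C/C(=C\c1cc(-c2ccccc2)cs1)C(N)=O` gives 2680 nM in a functional assay on MCF7 cells (Homo sapiens) for cytotoxicity, read by CCK-8 assay, with a stated time of 24 h; a higher number here means a weaker inhibitor, a lower number a stronger inhibitor. Compound 2 `C/C(=C\c1cc(-c2ccc(C)cc2)cs1)C(N)=O` gives > 50000 nM, a limit of this assay. Compound 3 `C/C(=C\c1cc(-c2ccc(S(C)(=O)=O)cc2)cs1)C(N)=O` gives > 50000 nM, likewise a limit.

Compound 3 therefore stands at the upper edge of what this assay reports, at a limit rather than a number (the limit of > 50000 nM in this assay, at which 2 of the 3 values shown sit). Compound 4 `COc1ccc(-c2csc(/C=C(\C)C(N)=O)c2)cc1` differs from compound 3 by methoxy in place of methylsulfonyl on an aromatic carbon. For the measured compounds named here, two measured steps bear on this place: an at least 18-fold higher number from compound 1 to compound 2 (1.27 log units; beyond the scatter) and an at least 18-fold higher number from compound 1 to compound 3 (1.27 log units; beyond the scatter), both large losses for a group put on this carbon, while a step that the two limits leave unreadable from compound 2 to compound 3 stays unreadable. A third group at the same place is thus expected to leave compound 4 near the limit, with the step of an at least 1.6-fold lower number from compound 3 to compound 4 (0.22 log units; that floor lies within the scatter) expected. Compound 4 is estimated at 30000 nM, between 5000 nM and 100000 nM.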

Compound 4, half-maximal inhibitory concentration: > 50000 nM
Compound 4 ended at the assay's limit (the forecaster's own chance of this, stated with the estimate: 55%); middle value at least 1.6-fold (0.22 log units) from the limit.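

Methoxy in place of hydrogen on this aromatic carbon gives an at least 18-fold higher number from compound 1 to compound 4 (1.27 log units; beyond the scatter) in this assay, making it the third group here to show a large loss. Of the compounds shown, only compound 1, with hydrogen at this place, gives a measured number. The steps among compound 2, compound 3 and compound 4 cannot be read, so methyl, methylsulfonyl and methoxy cannot be ranked: the limit of > 50000 nM in this assay, at which 3 of the 4 values shown sit.

On these data alone, whether any group on this carbon keeps a measurable value stays open, for example fluorine, an amine or a carboxylic acid. Also open, as far as these compounds go, is how these same groups would behave on another carbon of this ring.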